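The source may report more compounds than this note shows. Statements on the series, on what has been measured and on what is new or still open speak of the compounds shown alone.

Working notes on the series. Compound 1 `O=c1oc(CO)cc2ccccc12`, compound 2 `COc1ccc2cc(CCCO)oc(=O)c2c1` and compound 3 `CCCCCOCCCc1cc2ccc(OC)cc2c(=O)o1` share one core. In a functional assay on 786-0 cells (Homo sapiens) for antiproliferative activity, read by sulforhodamine B assay, with a stated time of 48 h (a lower number here means a stronger inhibitor of growth, a higher number a weaker inhibitor of growth), compound 1 gives >= 250 ug/mL, a limit of the assay rather than a number, as the limit of >= 250 ug/mL in this assay, at which 1 of the 3 values shown sits, records. Compound 2 gives 26.9 ug/mL in this assay. Compound 3 gives 25.5 ug/mL in this assay, and of the two numbers shown compound 3 and compound 2 lie within the scatter of each other, the step of a 1.1-fold lower number from compound 2 to compound 3 (0.02 log units; within the scatter) being within it. Compound 4 `COc1ccc2cc(CCCOCCCc3cccnc3)oc(=O)c2c1` differs from compound 3 by pyridin-3-yl in place of ethyl on a saturated chain carbon, three bonds along the chain from an oxygen on a saturated carbon. For the measured compounds named here, the only measured step on this chain, a 1.1-fold lower number from compound 2 to compound 3 (0.02 log units; within the scatter), was within the scatter, so no step beyond the scatter is expected in this assay. Compound 4 is therefore expected at 25 ug/mL, within 12 ug/mL to 50 ug/mL, an expected step of a 1.0-fold lower number from compound 3 to compound 4 (0.01 log units; within the scatter).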

Compound 4, concentration for 50% growth inhibition: 28.7 ug/mL
The estimate for compound 4 lay 1.1-fold (0.06 log units) below the measured number, and the stated range covers the measured number.
By their numbers in this assay, from the lowest: compounds 3, 2 and 4 (each within the scatter of the next). At a limit, above all of these: compound 1.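

In this assay the ethyl to pyridin-3-yl change on the saturated chain carbon, three bonds along the chain from an oxygen on a saturated carbon, gives a 1.1-fold higher number from compound 3 to compound 4 (0.05 log units; within the scatter) and so leaves the number unmoved. The earlier compounds shown here showed only an all-carbon pentyl group on this oxygen; compound 4 shows that a six-membered aromatic ring with 1 hetero atom can stand at the chain end without a step beyond the scatter. From the compounds shown here alone, whether an amine, a carboxylic acid or a longer chain here would move the number remains open, as does the effect of pyridin-4-yl in place of pyridin-3-yl. Nothing at hand bears on why this change leaves the number in place.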